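Fluorine for chlorine on the benzyl arm of compound 2

The source may hold more compounds than are shown below. What is called first, only, known or untested is meant among the compounds shown, and "the series" means these compounds.

Compound 2 `CCCSc1nc(N/N=C(\C)c2ccccc2O)c2nnn(Cc3ccccc3Cl)c2n1` was tested in a functional assay on MCF7 cells (Homo sapiens) for antiproliferative activity, read by MTT assay, with a stated time of 72 h (on this read-out higher numbers stand for weaker inhibition and lower numbers for stronger inhibition), and gave only a limit, > 64000 nM. Compound 1 `CCCSc1nc(N/N=C(\C)c2ccc(OC)cc2)c2nnn(Cc3ccccc3)c2n1` likewise gave only a limit in this assay, > 64000 nM. Compound 3 `C#CCSc1nc(N/N=C(\C)c2ccccc2O)c2nnn(Cc3ccccc3)c2n1` gave a number in this assay, 11300 nM. Compound 2 therefore stands at the limit of > 64000 nM in this assay, at which 2 of the 3 values shown sit, the weak end of what has been measured so far. Compound 4 `CCCSc1nc(N/N=C(\C)c2ccccc2O)c2nnn(Cc3ccc(F)cc3)c2n1` has not yet been measured and differs from compound 2 in one place: 4-fluorophenyl in place of 2-chlorophenyl on a saturated chain carbon bound to an aromatic nitrogen. For the measured compounds named here, no step between measured compounds is available, so the size of this change cannot be read from any neighbouring pair. The step from compound 2 to compound 4 is expected to stay within the usual scatter, an at least 1.0-fold lower number from compound 2 to compound 4 (0.02 log units; that floor lies within the scatter). Compound 4 is accordingly estimated at 60000 nM, between 20000 nM and 150000 nM, with a real chance that the assay again reports only a limit.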

Compound 4, half-maximal inhibitory concentration: > 64000 nM
Compound 4: a limit, no number; the forecaster's own chance of this, stated with the estimate: 60%; middle value at least 1.0-fold (0.02 log units) from the limit.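

For the compounds shown here, compound 2 and compound 4 both give only a limit in this assay, so no step between them can be read. The compounds shown leave open whether 2-chlorobenzyl and 4-fluorobenzyl differ at all in this assay.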